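This account rests on a few compounds, and the source may have more. Where it says the series, first, only, none or still open, it means among the compounds named here.

Working notes on the series. The shared core carries a carboxy group and a hydroxy group on a six-membered ring of carbon only, with a five-membered aromatic ring varied on one aromatic carbon. Compound 1 `O=C(O)c1cc(-n2ccnn2)ccc1O` carries 1H-1,2,3-triazol-1-yl and gives 150 mg/kg in a functional assay on the whole organism for inhibition, with Rattus norvegicus as the target, read by paw edema; a higher number here means that more compound is needed for the effect, a lower number that less compound is needed. Compound 2 `O=C(O)c1cc(-c2cscn2)ccc1O` carries 1,3-thiazol-4-yl; in this assay compound 2 gives 95 mg/kg. Compound 3 `O=C(O)c1cc(-c2cccs2)ccc1O` carries thiophen-2-yl and gives 60 mg/kg in this assay.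

Compound 2 stands between the other two numbers, and both of its steps are within the scatter: a 1.6-fold lower number from compound 1 to compound 2 (0.20 log units; within the scatter) and a 1.6-fold lower number from compound 2 to compound 3 (0.20 log units; within the scatter). Among the compounds with values here, only the step of a 2.5-fold lower number from compound 1 to compound 3 (0.40 log units; beyond the scatter) reaches beyond the scatter, and it is modest.

Compound 4 `O=C(O)c1cc(-n2cnnc2)ccc1O` is the next member. The change from compound 2 is 4H-1,2,4-triazol-4-yl in place of 1,3-thiazol-4-yl on an aromatic carbon. Within the data shown here, the step that bears most on this is the one from compound 1 to compound 2, which runs from a triazolyl ring to the thiazolyl ring and is within the scatter; the new change restores a triazolyl ring, so a small move back toward the number of compound 1 is expected, with no step beyond the scatter likely in this assay. For compound 4 the expected step is a 1.4-fold higher number from compound 2 to compound 4 (0.14 log units; within the scatter). In this assay compound 4 is estimated at 130 mg/kg, with a range from 65 mg/kg to 260 mg/kg.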

Compound 4, dose for half-maximal effect: > 250 mg/kg
Compound 4: only a limit was reported (the forecaster's own chance of this, stated with the estimate: 10%); middle value at least 1.9-fold (0.28 log units) from the limit.
By their numbers in this assay, from the lowest: compounds 3, 2 and 1 (each within the scatter of the next, the first and the last beyond it). At a limit, above all of these: compound 4.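

Compound 4 in this assay gives only a limit, not a number, with the 4H-1,2,4-triazol-4-yl group on the aromatic carbon para to a hydroxy group and meta to a carboxy group: the limit of > 250 mg/kg in this assay, at which 1 of the 4 values shown sits.

Within the data shown here, until now, the only step beyond the scatter at this position was a 2.5-fold lower number from compound 1 to compound 3 (0.40 log units; beyond the scatter), whereas the new group gives an at least 2.6-fold higher number from compound 2 to compound 4 (0.42 log units; beyond the scatter) and an at least 4.1-fold higher number from compound 3 to compound 4 (0.61 log units; beyond the scatter), so a change of ring at this position can separate compound 4 from both sulfur-containing members. The two triazolyl isomers cannot be ordered, since the step between them is an at least 1.6-fold higher number from compound 1 to compound 4 (0.22 log units; that floor lies within the scatter), and the floor of that step does not show that moving the ring nitrogens matters.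

From the compounds shown here alone, the true position of compound 4 beyond its limit remains open, and with it the full size of all three new steps. Also open is how this assay responds to an amine, a longer chain or a six-membered aromatic ring such as pyridine on the same aromatic carbon, as the compounds shown all carry a five-membered aromatic ring there.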